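A few compounds are considered here, and "the series" means these few. Any claim that something is new, unique, unknown or untested is made for them only; others in the source may bear on it.

Working notes on the series: in a functional assay on A549 cells (Homo sapiens) for cytotoxicity, read by MTT assay, with a stated time of 72 h (on this read-out higher numbers stand for weaker inhibition and lower numbers for stronger inhibition), compound 1 (`Cn1ccc2c(Oc3ccc(NC(=O)c4cc5cccnc5n(-c5ccc(C(F)(F)F)cc5Cl)c4=O)cc3)ncnc21`) gives 364000 nM, while compound 2 (`Cn1ccc2c(Oc3ccc(NC(=O)c4cc5cccnc5n(-c5ccc(Cl)cc5)c4=O)cc3F)ncnc21`) gives 55500 nM, the lower of the two numbers, with the gap beyond the scatter. Compound 3 (`Cn1ccc2c(Oc3ccc(NC(=O)c4cc5cccnc5n(-c5ccc(C(F)(F)F)cc5Cl)c4=O)cc3F)ncnc21`) follows from compound 2 with 2-chloro-4-(trifluoromethyl)phenyl in place of 4-chlorophenyl on an aromatic nitrogen. Within the data shown here, no measured step isolates this change. Compound 1 also carries the entering group and stands at 364000 nM, so a moderate rise towards weaker inhibition is expected in this assay. The expected size is a 2.2-fold higher number from compound 2 to compound 3 (0.33 log units; beyond the scatter). The estimate for compound 3 is 120000 nM, within 35000 nM to 400000 nM.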

Compound 3, half-maximal inhibitory concentration: "not active" (no number reported)
No number was reported for compound 3; the estimate stays without a comparison.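

Among these compounds, compound 3 carries no number, only "not active", and no step from compound 2 to compound 3 can be read in this assay. From the compounds shown here alone, the size of the effect of 2-chloro-4-(trifluoromethyl)phenyl in place of 4-chlorophenyl stays open, and no available evidence bears on this result.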